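Shortening a Side Chain on Two Related Cores

The source may report more compounds than this note shows. Statements on the series, on what has been measured and on what is new or still open speak of the compounds shown alone.

Compound 1 `CCc1ncn2c(S)nncc12`: in a functional assay for inhibition, with Homo sapiens as the target (a lower number here means a stronger inhibitor, a higher number a weaker inhibitor), compound 1 gives > 48000 nM, a limit of the assay rather than a number.
Compound 2 `CCCc1ncn2c(S)nncc12`: in this assay compound 2 gives > 48000 nM, again only a limit.
Compound 3 `CCCc1ncn2c(Nc3cc[nH]n3)nccc12`: in this assay compound 3 gives > 48000 nM, also a limit.

The change from compound 2 to compound 1 is hydrogen in place of methyl on a saturated chain carbon, two bonds along the chain from an aromatic carbon. Its size is a step that the two limits leave unreadable from compound 2 to compound 1 because both values sit at the limit (the limit of > 48000 nM in this assay, at which 3 of the 3 values shown sit). Compound 4 `CCc1ncn2c(Nc3cc[nH]n3)nccc12` carries the same change relative to compound 3, (hydrogen in place of methyl on a saturated chain carbon, two bonds along the chain from an aromatic carbon); the difference between the two cores is not broken down here. For the new step there is thus no measured size to lean on, only the fact that compound 3 is itself known as a limit > 48000 nM. The step from compound 3 to compound 4 is expected to be about a step that the limit leaves unreadable from compound 3 to compound 4. Compound 4 is therefore expected to give roughly 60000 nM, most likely reported again as a limit.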

Compound 4, half-maximal inhibitory concentration: 36000 nM
Compound 4: the middle estimate sits 1.7-fold (0.22 log units) above what was measured; measured number inside the range.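

In this assay, the change from propyl to ethyl on the core of compound 3 gives an at least 1.3-fold lower number from compound 3 to compound 4 (0.12 log units; that floor lies within the scatter). Compound 3 is known only as a limit, so the true step could be larger, but the part that can be read does not establish a real gain. Whether the change carries from one core to the other remains untested, because the step between compound 2 and compound 1 cannot be read: the limit of > 48000 nM in this assay, at which 3 of the 4 values shown sit.

The compounds shown leave open how a methyl or a butyl chain in place of the ethyl chain would read on the core of compound 4. On these data alone, an amine or a carboxylic acid on that chain is equally open.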